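The compounds below may be only part of what the source reports. "The series", "measured", "known", "first", "only" and "open" are said of these compounds alone.

Measured in a physicochemical assay for lipophilicity, read by LC-MS, in phosphate buffer, measured as octanol-water partition, with a stated time of 30 min, at pH 7.4, tested at 200 mM; on this read-out lower numbers stand for lower lipophilicity and higher numbers for higher lipophilicity:
compound 1 `Cn1c(COc2cccc(C(=O)O)c2)nc2cnc(Oc3ccc(Cl)c(F)c3)cc21`: 1.4
compound 2 `Cc1ccc(Oc2cc3c(cn2)nc(COc2cccc(C(=O)O)c2)n3C)cc1`: 1
compound 3 `Cc1ccc(Oc2ccc3nc(COc4cccc(C(=O)O)c4)n(C)c3c2)nc1`: 0.9

Compound 3 gives the smallest of the three numbers as read, but compound 2 lies within the scatter of it, so the two cannot be ordered; only compound 1 stands clearly higher than compound 3.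

Within the data shown here, the one step known in this set is a number 0.40 log units lower from compound 1 to compound 2 (beyond the scatter). In that step a 4-chloro-3-fluorophenyl left and a 4-methylphenyl entered, so a chlorine and a fluorine went out while a methyl came in.

Compound 4 `Cc1cc(F)cnc1Oc1ccc2nc(COc3cccc(C(=O)O)c3)n(C)c2c1` differs from compound 3 as follows: 5-fluoro-3-methylpyridin-2-yl in place of 5-methylpyridin-2-yl on an oxygen on an aromatic ring. Here the methyl on the ring is kept and a fluorine is added, which is in part the reverse of what happened from compound 1 to compound 2, though that step also removed a chlorine and is the only guide. A small rise in this assay is therefore expected for compound 4, of a size that may not clear the scatter.

The step is estimated as a number 0.20 log units higher from compound 3 to compound 4 (within the scatter). Compound 4 is expected to read 1.1, within a range of 0.8 to 1.5.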

Compound 4, distribution coefficient: 1.1
Compound 4: the middle estimate sits on the measured number at the digits printed; low and high end bracket the measured number.
By their numbers in this assay, from the lowest: compounds 3, 2, 4 and 1 (each within the scatter of the next, the first and the last beyond it).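

In this assay, among these compounds, 5-fluoro-3-methylpyridin-2-yl in place of 5-methylpyridin-2-yl on an oxygen on an aromatic ring gives a number 0.20 log units higher from compound 3 to compound 4 (within the scatter) and leaves the two compounds unordered, whereas the only other step at this place, a number 0.40 log units lower from compound 1 to compound 2 (beyond the scatter) on a different core and with phenyl groups, lies beyond the scatter. Among the compounds shown here, this place therefore accepts a fluorine on the pyridine, together with a shift of the methyl, without a readable difference on this read-out, and it shows for the first time a change between two substituted pyridines rather than two substituted phenyl groups. The fluorine and the methyl shift arrive as a single step and cannot be separated, and nothing available explains the reading.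

Still open, going by these compounds, is how each of the two changes reads alone, and whether the same pyridine exchange would give a similar step on the core of compound 1. Also open, on these data alone, is whether a more different group on this oxygen, such as an amine-bearing pyridine or a longer alkyl chain, would move the number beyond the scatter.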